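The compounds below may be only part of what the source reports. "The series", "measured", "known", "first", "only" and "open" are said of these compounds alone.

In a functional assay on SH-SY5Y cells (Homo sapiens) for cytotoxicity, read by MTT assay, with a stated time of 72 h (a higher number here means a weaker inhibitor, a lower number a stronger inhibitor), compound 2 `O=C1c2c[n+]([O-])c3ccccc3c2C(=O)c2[nH]c3ccccc3c21` gives 1380 nM and compound 1 `O=C1c2c[n+]([O-])c3ccccc3c2C(=O)c2c1c1ccccc1n2CCN1CCCCC1` gives 1860 nM, so the two stand within the scatter of each other. Compound 3 `O=C1c2c[n+]([O-])c3ccccc3c2C(=O)c2c1c1ccccc1n2CCCN1CCC(O)CC1` departs from compound 2 by one change: 3-(4-hydroxypiperidin-1-yl)propyl in place of hydrogen on an aromatic nitrogen. Going by the values given here, the one measured step that bears on it is a 1.3-fold lower number from compound 1 to compound 2 (0.13 log units; within the scatter), where hydrogen replaces 2-(piperidin-1-yl)ethyl on an aromatic nitrogen, and that step stayed within the scatter. No step beyond the scatter is therefore expected in this assay, and the expected change is a 1.1-fold higher number from compound 2 to compound 3 (0.04 log units; within the scatter). For compound 3 the estimated value is 1500 nM, with a range from 600 nM to 3800 nM.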

Compound 3, half-maximal inhibitory concentration: 130 nM
Beside the measured number, compound 3's estimate is 12-fold (1.06 log units) above it; the whole stated range lies above it.
By their numbers in this assay, from the lowest: compound 3; then compounds 2 and 1 (each within the scatter of the next).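

In this assay this aromatic nitrogen is not indifferent to substitution: 3-(4-hydroxypiperidin-1-yl)propyl gives an 11-fold lower number from compound 2 to compound 3 (1.03 log units; beyond the scatter), although the 2-(piperidin-1-yl)ethyl group of compound 1 stayed within the scatter of hydrogen. The side chain itself therefore matters, as the change in the chain gives a 14-fold lower number from compound 1 to compound 3 (1.16 log units; beyond the scatter). Nothing available explains this difference. Chain length and the 4-hydroxy group change together between compound 1 and compound 3, so their shares remain open. A 3-(piperidin-1-yl)propyl or 2-(4-hydroxypiperidin-1-yl)ethyl chain would separate them.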